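Thiophene to chlorophenyl on the shared core

The source may report more compounds than this note shows. Statements on the series, on what has been measured and on what is new or still open speak of the compounds shown alone.

Of the compounds shown here, three on the shared core have been measured in a functional assay on HeLa cells (Homo sapiens) for cytotoxicity, read by MTT assay, with a stated time of 48 h; a higher number here means a weaker inhibitor, a lower number a stronger inhibitor. Compound 1 `COc1ccccc1C(C1=C(O)C(=O)c2ccccc2C1=O)c1c[nH]c2ccccc12` gives 128000 nM. Compound 2 `Cc1[nH]c2ccccc2c1C(C1=C(O)C(=O)c2ccccc2C1=O)c1ccc(Cl)cc1` gives 8030 nM. Compound 3 `O=C1C(O)=C(C(c2cccs2)c2c[nH]c3ccccc23)C(=O)c2ccccc21` gives 12400 nM; its number lies far below that of compound 1 and close to that of compound 2, from which it differs in two places. The only single-point step among these is a 10-fold lower number from compound 1 to compound 3 (1.01 log units; beyond the scatter), which shows that a swap at this chain carbon can move the number a long way.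

Compound 4 `O=C1C(O)=C(C(c2ccc(Cl)cc2)c2c[nH]c3ccccc23)C(=O)c2ccccc21` has not been measured. It differs from compound 3 by 4-chlorophenyl in place of thiophen-2-yl on a saturated chain carbon bound to an aromatic carbon and a double-bonded ring carbon. Within the data shown here, no measured step exchanges thiophen-2-yl for 4-chlorophenyl directly, so the step from compound 1 to compound 3 bears on it only as a sign of how much this position can matter. Compound 2 already carries 4-chlorophenyl at the same place and, with 8030 nM, sits close to compound 3; that makes a step in this assay of no more than the usual scatter the likelier outcome for compound 4, estimated as a 1.4-fold lower number from compound 3 to compound 4 (0.14 log units; within the scatter). Compound 4 is therefore expected to give about 9000 nM in this assay, within a range from 3500 nM to 25000 nM.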

Compound 4, half-maximal inhibitory concentration: 37000 nM
Estimate against measurement, compound 4: 4.1-fold (0.61 log units) below, outside the stated range (above it).
By their numbers in this assay, from the lowest: compounds 2 and 3 (each within the scatter of the next); then compound 4; then compound 1.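

In this assay, among these compounds, a 3.0-fold higher number from compound 3 to compound 4 (0.47 log units; beyond the scatter) gives the first direct reading of 4-chlorophenyl against thiophen-2-yl at this chain carbon, and the two groups are not interchangeable there. With a 3.5-fold lower number from compound 1 to compound 4 (0.54 log units; beyond the scatter) alongside it, the three groups can be placed in order on the unmethylated core, with thiophen-2-yl giving the lowest number, 4-chlorophenyl the middle one and 2-methoxyphenyl the highest, each separated beyond the scatter. The result also reveals a second sensitive place, since a 4.6-fold higher number from compound 2 to compound 4 (0.66 log units; beyond the scatter) shows that the methyl on an aromatic carbon matters as well, so the number for a group at the chain carbon cannot be carried over from a compound that also differs at that aromatic carbon, and the compounds shown offer no evidence that explains either change.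

Among the compounds shown here, whether the methyl on the aromatic carbon acts to the same extent alongside thiophen-2-yl or 2-methoxyphenyl remains open, as the methyl step is seen only with 4-chlorophenyl. Also open, on these data alone, is how the number would respond to an amine or a carboxylic acid on the aromatic ring at the chain carbon.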